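The compounds below may be only part of what the source reports. "The series", "measured", "known", "first", "only" and "open" are said of these compounds alone.

Compound 1 `C[C@@H](Cn1c(=O)[nH]/c(=N\c2ccc(Oc3nccs3)cc2)n(Cc2ccc(Cl)cc2)c1=O)C(=O)O`: 0.006
Compound 2 `CC(C)Oc1ccc(/N=c2\[nH]c(=O)n(CC(C)(C)C(=O)O)c(=O)n2Cc2ccc(Cl)cc2)cc1Cl`: 0.003
Compound 3 `C[C@@H](Cn1c(=O)[nH]/c(=N\c2ccc(Oc3ccccn3)cc2)n(Cc2ccc(Cl)cc2)c1=O)C(=O)O`: 0.01

In an ADME assay on the whole organism (plasma, Rattus norvegicus) for protein binding, using cassette dosing, at a dose of 1 mg/kg (a lower number here means a smaller unbound share, a higher number a larger unbound share of the compound), compound 3 gives the highest of the three numbers. Compound 1 sits nearest to it, separated by a 1.7-fold higher number from compound 1 to compound 3 (0.22 log units; within the scatter), a gap the usual scatter covers. Going by the values given here, compound 2 gives the lowest number, and the gap between compound 2 and compound 3 lies beyond the scatter; no single-point step is drawn between those two, since compound 2 differs from compound 3 in more than one place.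

Compound 4 `C[C@@H](Cn1c(=O)[nH]/c(=N\c2ccc(Oc3cncc(F)c3)cc2)n(Cc2ccc(Cl)cc2)c1=O)C(=O)O` has not yet been measured. It differs from compound 3 in one place: 5-fluoropyridin-3-yl in place of pyridin-2-yl on an oxygen on an aromatic ring. Among the compounds with values here, the one measured step that touches the same oxygen on an aromatic ring is a 1.7-fold higher number from compound 1 to compound 3 (0.22 log units; within the scatter), an exchange of one aromatic heterocycle for another at that oxygen which stayed within the scatter. On that basis a change of like kind in this assay is expected to leave compound 4 close to compound 3, with no step beyond the scatter, though the fluorine of the entering group has no measured counterpart among these compounds. Compound 4 is therefore estimated at 0.008, with a range from 0.004 to 0.016, which means an expected step of a 1.3-fold lower number from compound 3 to compound 4 (0.10 log units; within the scatter).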

Compound 4, unbound fraction: 0.02
Estimate against measurement, compound 4: 2.5-fold (0.40 log units) below; the whole stated range lies below it.
By their numbers in this assay, from the lowest: compounds 2, 1, 3 and 4 (each within the scatter of the next, the first and the last beyond it).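

In this assay, the exchange at this oxygen on an aromatic ring now gives a step beyond the scatter: a 3.3-fold higher number from compound 1 to compound 4 (0.52 log units; beyond the scatter), although modest in size. Neither single exchange that passes through compound 3 shows this on its own, since a 1.7-fold higher number from compound 1 to compound 3 (0.22 log units; within the scatter) and a 2.0-fold higher number from compound 3 to compound 4 (0.30 log units; within the scatter) both stay within the scatter, so the position's effect on the unbound share appears only when the 1,3-thiazol-2-yl and 5-fluoropyridin-3-yl compounds are set against each other. Nothing measured here accounts for this difference.

The step from compound 3 to compound 4 moves the point of attachment on the pyridine ring and adds a fluorine in a single exchange, so the compounds shown cannot assign the result to either part; a plain pyridin-3-yl or a 5-fluoropyridin-2-yl would be needed to separate them. On these data alone, it also remains open whether a chlorine or a methoxy group in the place of that fluorine would give a similar number, and whether 5-fluoropyridin-3-yl would act in the same way alongside the dimethyl-substituted carboxylic acid chain of compound 2.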